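Aortic relaxation series: swapping chloro for methoxy on aniline

The source may report more compounds than this note shows. Statements on the series, on what has been measured and on what is new or still open speak of the compounds shown alone.

Measured compounds:
Compound 1: `CCOC(=O)c1c(-c2ccc(F)cc2)cc(-c2ccccc2)nc1Nc1ccc(Cl)cc1` — 715000 nM
Compound 2: `CCOC(=O)c1c(-c2ccc(C)cc2)cc(-c2ccccc2)nc1Nc1ccc(Cl)cc1` — 266000 nM

In a functional assay on thoracic aorta (strain Wistar) with Aorta (Rattus norvegicus) as the target, with a stated time of 2 h (a higher number here means a weaker inhibitor, a lower number a stronger inhibitor), compound 2 gives the lowest of the two numbers; its nearest neighbour is compound 1, which lies a 2.7-fold lower number from compound 1 to compound 2 (0.43 log units; beyond the scatter) higher, a step made by methyl in place of fluoro on an aromatic carbon. Compound 3 is `CCOC(=O)c1c(-c2ccc(C)cc2)cc(-c2ccccc2)nc1Nc1ccc(OC)cc1`, which is not yet measured. It differs from compound 2 by methoxy in place of chloro on an aromatic carbon. Among the compounds with values here, no measured step touches this position: the only step in hand concerns the other aryl ring, so it offers no guide to what a change on the aniline ring should do in this assay. With nothing to point either way, compound 3 is expected to sit close to compound 2, the step estimated at a 1.1-fold higher number from compound 2 to compound 3 (0.05 log units; within the scatter), within the scatter. Compound 3 is therefore estimated at 300000 nM, with a range from 100000 nM to 900000 nM.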

Compound 3, half-maximal inhibitory concentration: 233000 nM
Estimate against measurement, compound 3: 1.3-fold (0.11 log units) above; the range from low to high includes it.
By their numbers in this assay, from the lowest: compounds 3 and 2 (each within the scatter of the next); then compound 1.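

Within the data shown here, at the place on the aniline ring para to a large group, the step from 4-chlorophenyl to 4-methoxyphenyl gives the first reading for this position in this assay (a 1.1-fold lower number from compound 2 to compound 3 (0.06 log units; within the scatter)). Chloro and methoxy, which differ in size and in the hydrogen-bond acceptor that methoxy brings, therefore read alike here, something the earlier step on the other aryl ring could not show. Nothing measured here accounts for this likeness.

Chloro and methoxy are the only groups shown at this position, so an amine, a carboxylic acid or a longer alkyl chain there could still read quite differently. From the compounds shown here alone, it also remains open whether methoxy and chloro would read alike with fluoro in place of methyl on the other aryl ring.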